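This account rests on a few compounds, and the source may have more. Where it says the series, first, only, none or still open, it means among the compounds named here.

Series notes.
Compound 1 `c1cc(N2CCCCC2)nc(Nc2ccc(Oc3ncnc4sccc34)cc2)n1` gives 66.3% in a functional assay on HCT-116 cells (Homo sapiens) for inhibition, read by MTT assay, with a stated time of 72 h, tested at 20 uM; a higher number here means more inhibition at the concentration tested (going by the name of the read-out), a lower number less inhibition.
Compound 2 `c1ccc2c(c1)CCN(c1ccnc(Nc3ccc(Oc4ncnc5sccc45)cc3)n1)C2` gives 18.1% in this assay.

Compound 1 stands highest of the two numbers; the nearest, compound 2, sits lower by a number 48.2 percentage points lower from compound 1 to compound 2 (beyond the scatter), a large step beyond the scatter, on exchange of 1,2,3,4-tetrahydroisoquinolin-2-yl for piperidin-1-yl on an aromatic carbon.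

Compound 3 `c1cc(N2CCCCC2)nc(Nc2ccc(Oc3ncnc4ccsc34)cc2)n1` is not yet measured. It differs from compound 1 on the oxygen on an aromatic ring: a group of 9 heavy atoms (6 carbon, 2 nitrogen, 1 sulfur; one five-membered aromatic ring with 1 hetero atom, one six-membered aromatic ring with 2 hetero atoms) in place of a group of 9 heavy atoms (6 carbon, 2 nitrogen, 1 sulfur; one five-membered aromatic ring with 1 hetero atom, one six-membered aromatic ring with 2 hetero atoms), on an oxygen on an aromatic ring. The two compounds hold the same atoms, joined differently.

Among the compounds with values here, no measured step touches this part of the molecule: the one known step alters the group on the aromatic carbon and says nothing about the group on the oxygen. Within the data shown here, with no precedent, the expected step in this assay is none beyond the scatter, with a wide range allowed either way. The expected step is a number 11.3 percentage points lower from compound 1 to compound 3 (beyond the scatter). For compound 3 the estimate is 55%, ranging from 25% to 80%.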

Compound 3, a percentage reported as inhibition, at one concentration (the size of the read-out at that concentration, not a potency): 61.5%
Compound 3: middle estimate off by 6.5 percentage points, on the low side; measured number inside the range.
By their numbers in this assay, from the lowest: compound 2; then compounds 3 and 1 (each within the scatter of the next).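

Within the data shown here, the first measured change at the group on an oxygen on an aromatic ring, which holds the same atoms joined differently, gives a number 4.8 percentage points lower from compound 1 to compound 3 (within the scatter) in this assay. Among these compounds, for this pair, the rearrangement therefore leaves the read-out within the scatter, whereas the one earlier step, at the aromatic carbon, is a number 48.2 percentage points lower from compound 1 to compound 2 (beyond the scatter) and lies beyond it. Nothing available accounts for either outcome.

Among the compounds shown here, it remains open whether the rearranged group would behave the same way with 1,2,3,4-tetrahydroisoquinolin-2-yl on the aromatic carbon, as the only comparison here carries piperidin-1-yl. Also open is how a morpholin-4-yl or dimethylamino group at that carbon, or a plain phenyl group on the oxygen, would read in this assay, and a percentage at one concentration gives no potency for any of these compounds.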